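The compounds below may be only part of what the source reports. "The series", "measured", "known", "first", "only" and "open" are said of these compounds alone.

Measured compounds:
Compound 1, `Cc1nc2nc(-c3ccccc3)cc(C(F)(F)F)c2c(=O)n1Cc1cn(CCC(F)(F)C(F)(F)C(F)(F)C(F)(F)C(F)(F)C(F)(F)F)nn1`, in a functional assay on COLO 205 cells (Homo sapiens) for cytotoxicity, read by MTT assay, with a stated time of 24 h (a higher number here means a weaker inhibitor, a lower number a stronger inhibitor), gives > 200 ug/mL, which is a limit of the assay and not a number.
Compound 2, `Cc1nc2nc(-c3ccccc3)cc(C(F)(F)F)c2c(=O)n1Cc1cn(CCC(F)(F)C(F)(F)C(F)(F)C(F)(F)C(F)(F)C(F)(F)C(F)(F)C(F)(F)F)nn1`, gives in this assay > 200 ug/mL, again a limit of the assay.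
Compound 3, `Cc1nc2nc(-c3ccccc3)cc(C(F)(F)F)c2c(=O)n1Cc1cn(-c2ccccc2)nn1`, gives in this assay > 200 ug/mL, also a limit of the assay.

Compound 1 stands where the other two stand: every value shown sits at the limit of > 200 ug/mL in this assay, at which 3 of the 3 values shown sit, and none of them is a number. Among the compounds with values here, the one step among the measured compounds that changes a single place, a step that the two limits leave unreadable from compound 1 to compound 2, runs between two limits and therefore yields no size. Compound 4 is `CCc1nc2nc(-c3ccccc3)cc(C(F)(F)F)c2c(=O)n1Cc1cn(CCC(F)(F)C(F)(F)C(F)(F)C(F)(F)C(F)(F)C(F)(F)F)nn1`. It differs from compound 1 by methyl in place of hydrogen on a saturated chain carbon bound to an aromatic carbon. Within the data shown here, no measured step touches this place; the single measured step bears on compound 4 only by showing that a change at the far end of the chain left the value at the limit, and the move to compound 3 shows the same. There is thus no footing for a step in either direction beyond the scatter, and the expectation for this assay is that compound 4 also returns a limit. The step that this estimate means, a step that the limit leaves unreadable from compound 1 to compound 4, is expected to be nothing beyond the scatter. Compound 4 is estimated at 250 ug/mL, within a range from 150 ug/mL to 1200 ug/mL, with the likelier outcome that only a limit is reported.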

Compound 4, half-maximal inhibitory concentration: > 200 ug/mL
Compound 4 was reported as a limit; the forecaster's own chance of this, stated with the estimate: 85%; the middle value does not contradict the limit.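

In this assay compound 4 gives > 200 ug/mL, a limit of the assay and not a number. Compound 1 also stands at a limit, so no step can be read between compound 1 and compound 4. The compounds shown leave open whether any change to them would give a measurable value, as all remain at one limit: the limit of > 200 ug/mL in this assay, at which 4 of the 4 values shown sit.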